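Swapping Chloro for Methyl on a Leukotriene Antagonist

The source may report more compounds than this note shows. Statements on the series, on what has been measured and on what is new or still open speak of the compounds shown alone.

Measured so far:
Compound 1, `CCC(CC)(CC(=O)Nc1cccc(OCc2ccc3ccc(Cl)cc3n2)c1)C(=O)O`: 0.8 nM
Compound 2, `CCC(CC)(CC(=O)Nc1cccc(OCc2ccc3ccccc3n2)c1)C(=O)O`: 0.9 nM

Compound 1 has the lowest of the two numbers in a functional assay on ileum (Cavia porcellus) for antagonist activity at cysteinyl leukotriene receptor (Homo sapiens); a lower number here means a stronger inhibitor, a higher number a weaker inhibitor; its nearest neighbour is compound 2, and the two values lie within the usual scatter of each other, so no order can be read from them. Within the data shown here, the only step with a bearing here runs a 1.1-fold higher number from compound 1 to compound 2 (0.05 log units; within the scatter), meaning that removing the chloro changed the read-out no more than repetition would.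

Compound 3, `CCC(CC)(CC(=O)Nc1cccc(OCc2ccc3ccc(C)cc3n2)c1)C(=O)O`, differs from compound 1 by methyl in place of chloro on an aromatic carbon. Since the loss of the same chloro left this assay unchanged beyond scatter in the step from compound 1 to compound 2, the methyl in its place is expected to do the same. The expected step is a 1.1-fold higher number from compound 1 to compound 3 (0.05 log units; within the scatter), essentially no change. Compound 3 is therefore estimated at 0.9 nM, with a range from 0.4 nM to 2 nM.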

Compound 3, half-maximal inhibitory concentration: 11 nM
For compound 3 the middle estimate is 12-fold (1.09 log units) below the measured one; measured number above the stated range.
By their numbers in this assay, from the lowest: compounds 1 and 2 (each within the scatter of the next); then compound 3.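

Adding a methyl at this position is not a neutral change: in this assay, the hydrogen-to-methyl change gives a 12-fold higher number from compound 2 to compound 3 (1.09 log units; beyond the scatter), and the chloro-to-methyl change gives a 14-fold higher number from compound 1 to compound 3 (1.14 log units; beyond the scatter). The position therefore responds strongly to what it carries, even though hydrogen and chloro alone gave a 1.1-fold higher number from compound 1 to compound 2 (0.05 log units; within the scatter) and so had suggested otherwise. Chloro and methyl each count as one heavy atom, with no hydrogen-bond donors or acceptors and no net charge, so these counts do not separate them, and no measurement available here explains the gap.

Going by these compounds, whether the weaker result belongs to methyl alone or extends to other groups here, such as fluoro, methoxy or a longer chain like ethyl, remains open. On these data alone, it is also open whether chloro and methyl would differ as sharply elsewhere on the same ring.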